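Replacing azetidin-1-yl with dimethylamino on a carbonyl carbon

The compounds below may be only part of what the source reports. "The series", "measured", "known", "first", "only" and "open" are said of these compounds alone.

In a functional assay on HCT-116 cells (Homo sapiens) for antiproliferative activity, read by sulforhodamine B assay, with a stated time of 4 days (on this read-out lower numbers stand for stronger inhibition of growth and higher numbers for weaker inhibition of growth), compound 1 (`COc1cc(Cl)c(-c2nc(SCC(=O)NC(C)(C)C)nc3[nH]cc(C#N)c23)cc1O`) gives 117 nM and compound 2 (`COc1cc(Cl)c(-c2nc(SCC(=O)N3CCC3)nc3[nH]cc(C#N)c23)cc1O`) gives 172 nM which lies within the scatter of compound 1. Compound 3 (`COc1cc(Cl)c(-c2nc(SCC(=O)N(C)C)nc3[nH]cc(C#N)c23)cc1O`) has not yet been measured. It carries dimethylamino in place of azetidin-1-yl on a carbonyl carbon. Among the measured compounds shown here, only one measured step bears on this change (a 1.5-fold higher number from compound 1 to compound 2 (0.17 log units; within the scatter)) and it put azetidin-1-yl in place of (tert-butyl)amino on a carbonyl carbon. For the measured compounds named here, that step lies within the scatter, and no measured compound carries dimethylamino. No step beyond the scatter is therefore expected in this assay and no direction can be given. The expected step (a 1.0-fold lower number from compound 2 to compound 3 (0.01 log units; within the scatter)) stays within the scatter. Compound 3 is estimated at 170 nM with a range from 70 nM to 400 nM on this read-out.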

Compound 3, concentration for 50% growth inhibition: 131 nM
Estimate against measurement, compound 3: 1.3-fold (0.11 log units) above; the range from low to high includes it.
By their numbers in this assay, from the lowest: compounds 1, 3 and 2 (each within the scatter of the next).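

In this assay, dimethylamino in place of azetidin-1-yl on the carbonyl carbon gives a 1.3-fold lower number from compound 2 to compound 3 (0.12 log units; within the scatter) and dimethylamino in place of (tert-butyl)amino gives a 1.1-fold higher number from compound 1 to compound 3 (0.05 log units; within the scatter). A group without a ring at this place thus joins the azetidin-1-yl and (tert-butyl)amino amides, and the three cannot be told apart in this assay, so the position has so far shown no measurable response to these small amide groups. Nothing available explains this result.

The compounds shown leave open whether any amide group at this place can move the number beyond the scatter. A morpholin-4-yl ring, a longer chain ending in an amine, or a carboxylic acid on the carbonyl carbon's amide nitrogen could test that.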